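The source may report more compounds than this note shows. Statements on the series, on what has been measured and on what is new or still open speak of the compounds shown alone.

The account follows a single pair of compounds. Compound 1 `O=C1O/C(=C\Cn2cnc3c(Cl)c(F)nc(F)c32)C(OCc2ccccc2)=C1OCc1ccccc1` is known only as a limit in a functional assay on HeLa cells (Homo sapiens) for antiproliferative activity, read by MTT assay, with a stated time of 72 h; on this read-out higher numbers stand for weaker inhibition and lower numbers for stronger inhibition: in this assay compound 1 gives > 100000 nM, which is a limit of the assay and not a measured number, as the limit of > 100000 nM in this assay, at which 1 of the 3 values shown sits, shows. Two other compounds have numbers. Compound 2 `O=C1NC(O)(CCn2cnc3cc[nH]c3c2=O)C(OCc2ccccc2)=C1OCc1ccccc1` gives 92000 nM in this assay. Compound 3 `O=C1O/C(=C\Cn2cnc3ccn(C/C=C4\OC(=O)C(OCc5ccccc5)=C4OCc4ccccc4)c3c2=O)C(OCc2ccccc2)=C1OCc1ccccc1` gives 5600 nM in this assay, a lower value than compound 2. Among the measured compounds shown here, since compound 1 stands at the limit, no step between measured compounds can be drawn from it, and none is recorded between compound 2 and compound 3, which differ in many places at once.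

The unmeasured compound 4 `O=C1O/C(=C\Cn2cnc3ccnc(Cl)c32)C(OCc2ccccc2)=C1OCc1ccccc1` differs from compound 1 in one place: a group of 10 heavy atoms (6 carbon, 3 nitrogen, 1 chlorine; one five-membered aromatic ring with 2 hetero atoms, one six-membered aromatic ring with 1 hetero atom) in place of a group of 12 heavy atoms (6 carbon, 3 nitrogen, 2 fluorine, 1 chlorine; one five-membered aromatic ring with 2 hetero atoms, one six-membered aromatic ring with 1 hetero atom), on a saturated chain carbon bound to a double-bonded chain carbon. With compound 1 giving only a limit, the step to compound 4 has no measured anchor, and the expectation is that the change stays within the usual scatter of this assay. The step from compound 1 to compound 4 is expected to be a number no higher from compound 1 to compound 4 (the limit leaves the size open), which is no change beyond the scatter. Compound 4 is therefore estimated at 100000 nM in this assay, with a range from 30000 nM to 300000 nM, and it may well again come back as a limit.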

Compound 4, half-maximal inhibitory concentration: > 100000 nM
Compound 4: only a limit was reported; the forecaster's own chance of this, stated with the estimate: 55%; the middle value lies on the limit itself.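

In this assay, among the compounds shown here, compound 4 gives > 100000 nM, which is a limit of the assay and not a measured number; compound 1 is likewise known only as a limit, so no step between compound 1 and compound 4 can be read. The compounds shown leave open whether exchanging these two groups changes the inhibition at all.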